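This account rests on a few compounds, and the source may have more. Where it says the series, first, only, none or still open, it means among the compounds named here.

Working notes on the series. In a functional assay on COLO 205 cells (Homo sapiens) for inhibition, read by sulforhodamine B assay, with a stated time of 48 h, tested at 50 uM (a lower number here means less inhibition of growth, a higher number more inhibition of growth at the concentration tested), compound 2 `O=C1C(=O)N(CCCn2cc(COc3cc(=O)oc4ccccc34)nn2)c2ccccc21` gives 75%. Compound 1 `COc1ccc2c(c1)C(=O)C(=O)N2CCCn1cc(COc2cc(=O)oc3ccccc23)nn1` differs from it by methoxy in place of hydrogen on an aromatic carbon; in this assay compound 1 gives 48%, the step being a number 27 percentage points lower from compound 2 to compound 1 (beyond the scatter). Compound 3 `O=C1C(=O)N(CCCCCn2cc(COc3cc(=O)oc4ccccc34)nn2)c2ccccc21` carries a longer chain between the two ring systems; how its core differs from that of compound 2 is not broken down here. In this assay compound 3 gives 62%, a number that stands below compound 2 and above compound 1, both gaps beyond the scatter.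

Compound 4 `COc1ccc2c(c1)C(=O)C(=O)N2CCCCCn1cc(COc2cc(=O)oc3ccccc23)nn1` awaits measurement. It differs from compound 3 by methoxy in place of hydrogen on an aromatic carbon, the same change as from compound 2 to compound 1, the place being the same word for word; the change occurs twice among the compounds shown. Within the data shown here, the one precedent for it is a number 27 percentage points lower from compound 2 to compound 1 (beyond the scatter). On that single precedent the expected step is a number 25 percentage points lower from compound 3 to compound 4 (beyond the scatter). Whether the longer chain alters the size of the step is not shown by any pair here. Compound 4 is expected to give 37% in this assay, with a range of 20% to 55%.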

Compound 4, percent growth inhibition at one concentration: 19%
For compound 4 the middle estimate is 18 percentage points above the measured one, outside the stated range (below it).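

In this assay the methoxy change again lowers growth inhibition, the new step being a number 43 percentage points lower from compound 3 to compound 4 (beyond the scatter), so the direction seen on the core of compound 2 also appears on the core of compound 3. The size of the step does not carry over, and an estimate taken from one core understates the step on the other: the same change on two cores in this assay, a number 27 percentage points lower (beyond the scatter) from compound 2 to compound 1 and a number 43 percentage points lower (beyond the scatter) from compound 3 to compound 4, 16 percentage points apart, beyond the scatter of two such steps

Among these compounds, with only one pair at each chain length, these results do not show whether a longer chain generally enlarges the methoxy step, what produces the difference, or whether the same direction would hold on any further core.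

The compounds shown leave open how another group on the same aromatic carbon, such as chlorine, a hydroxyl or an amine, would compare with hydrogen and methoxy. They also leave open how the step would run with a still longer chain between the two ring systems.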